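Replacing the Imidazolone-Bearing Side Chain with an Ester Triazole

This account rests on a few compounds, and the source may have more. Where it says the series, first, only, none or still open, it means among the compounds named here.

Compound 1 `CCO/C(O)=C1\C(COCCn2cc(N)n(C)c2=O)=NC(C)=C(C(=O)OC)C1c1ccccc1Cl` is the stronger of the two measured compounds: in a functional assay (aorta) with Rattus norvegicus as the target (a lower number here means a stronger inhibitor, a higher number a weaker inhibitor), compound 1 gives 25.1 nM, the lowest of the two numbers. Its neighbour, compound 2 `CCO/C(O)=C1\C(COCCn2nncc2C(N)=O)=NC(C)=C(C(=O)OC)C1c1ccccc1Cl`, gives 100 nM in this assay, and the step of a 4.0-fold higher number from compound 1 to compound 2 (0.60 log units; beyond the scatter) shows a modest loss when a five-membered ring with three hetero atoms takes the place of one with two, on a saturated chain carbon, two bonds along the chain from an oxygen on a saturated carbon.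

Compound 3 `CCOC(=O)c1cn(CCOCC2=NC(C)=C(C(=O)OC)C(c3ccccc3Cl)/C2=C(\O)OCC)nn1` makes a change at the same place: a group of 10 heavy atoms (5 carbon, 3 nitrogen, 2 oxygen; one five-membered aromatic ring with 3 hetero atoms) in place of a group of 8 heavy atoms (4 carbon, 3 nitrogen, 1 oxygen; one five-membered aromatic ring with 2 hetero atoms), on a saturated chain carbon, two bonds along the chain from an oxygen on a saturated carbon

Within the data shown here, the only step that bears on this is the one from compound 1 to compound 2, since it too brings in a five-membered aromatic ring with three hetero atoms at this place, and cost a modest loss. Compound 3 carries a 4-(ethoxycarbonyl)-1H-1,2,3-triazol-1-yl group instead of the ring of compound 2, so its number is expected to move in the same direction, by a 3.2-fold higher number from compound 1 to compound 3 (0.50 log units; beyond the scatter). Compound 3 is therefore estimated at 80 nM in this assay, with a likely range from 30 nM to 250 nM.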

Compound 3, half-maximal inhibitory concentration: 50.1 nM
Estimate against measurement, compound 3: 1.6-fold (0.20 log units) above; the measured number falls inside the stated range.
By their numbers in this assay, from the lowest: compounds 1, 3 and 2 (each within the scatter of the next, the first and the last beyond it).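

Putting 4-(ethoxycarbonyl)-1H-1,2,3-triazol-1-yl at this place in the core of compound 1 gives only a small step in this assay (a 2.0-fold higher number from compound 1 to compound 3 (0.30 log units; within the scatter)), so this large exchange of groups brings no loss that can be told apart from ordinary variation between repeat measurements. Exchanging the 5-carbamoyl-1H-1,2,3-triazol-1-yl group for that same ester-bearing triazole also gives a step too small to read (a 2.0-fold lower number from compound 2 to compound 3 (0.30 log units; within the scatter)), even though the two other compounds do stand apart by more than the scatter. A five-membered aromatic ring with three hetero atoms at this place therefore does not by itself bring a clear loss, and nothing measured on these compounds explains how the numbers fall.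

Only three groups are shown at this place, so it stays open how a carboxylic acid or a simple amine on the same saturated chain carbon would read in this assay. The two triazoles also differ in both the attached group and its place on the ring, and these compounds cannot separate those two changes.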